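The source may report more compounds than this note shows. Statements on the series, on what has been measured and on what is new or still open speak of the compounds shown alone.

Two compounds of the series have been taken through a functional assay on RAW264.7 cells (Mus musculus) for inhibition, read by Griess assay, with stated times of 3 h and 24 h (a higher number here means a weaker inhibitor, a lower number a stronger inhibitor), so far. Compound 1, `C=C1CC[C@H]2[C@@](C)(CCC(=O)N[C@@]2(C)COC(=O)c2ccccc2)[C@@H]1/C=C/C1=CCOC1=O`, returns in this assay only a limit, > 50000 nM. Compound 2, `C=C1CC[C@H]2[C@@](C)(CC[C@@H](O)[C@@]2(C)NC=O)[C@@H]1/C=C/C1=CCOC1=O`, likewise reaches only a limit in this assay, > 50000 nM. For the measured compounds named here, compound 2 therefore stands at the point of the limit of > 50000 nM in this assay, at which 2 of the 2 values shown sit, so nothing between the measured pair can be resolved and no step between them is counted.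

Compound 3, `C=C1CC[C@H]2[C@@](C)(CC[C@@H](OC(=O)c3cccnc3)[C@@]2(C)NC=O)[C@@H]1/C=C/C1=CCOC1=O`, is the next member awaiting this assay. It differs from compound 2 by (pyridin-3-yl)carbonyl in place of hydrogen on an oxygen on a saturated carbon, so the change sits on the oxygen on the saturated carbon whose other neighbour is a saturated ring carbon.

With both measured values resting at the limit, the expected step that the limit leaves unreadable from compound 2 to compound 3 is none beyond the scatter, and compound 3 is estimated at 60000 nM, within 15000 nM to 200000 nM, most likely again reported as a limit.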

Compound 3, half-maximal inhibitory concentration: > 50000 nM
Compound 3: a limit, no number; the forecaster's own chance of this, stated with the estimate: 70%; the middle value is on the limit's open side.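

No step can be read from compound 2 to compound 3, as both results are limits and not numbers: the limit of > 50000 nM in this assay, at which 3 of the 3 values shown sit.

The compounds shown leave open whether any member of the series gives a measurable inhibition, and whether (pyridin-3-yl)carbonyl in place of hydrogen changes it at all.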